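Nitrooxy cinnamate series: chain extension from compound 2

A few compounds are considered here, and "the series" means these few. Any claim that something is new, unique, unknown or untested is made for them only; others in the source may bear on it.

Three members of the series have been tested in a functional assay on NCI-H460 cells (Homo sapiens) for cytotoxicity, read by resazurin assay, with a stated time of 72 h; a higher number here means a weaker inhibitor, a lower number a stronger inhibitor. Compound 1, `COc1cc(/C=C/C(=O)OCCCCCO[N+](=O)[O-])ccc1OCCCCCO[N+](=O)[O-]`, carries the nitrooxy-bearing chain on both the ester oxygen and the phenol oxygen; in this assay compound 1 returns only a limit, > 50000 nM. Going by the values given here, compound 2, `COc1cc(/C=C/C(=O)OCCCCCO[N+](=O)[O-])ccc1O`, keeps the free phenol, and in this assay compound 2 gives 12300 nM, the only actual number in the set. Compound 3, `COc1cc(/C=C/C(=O)OCCOc2no[n+]([O-])c2S(=O)(=O)c2ccccc2)ccc1O`, likewise returns only a limit in this assay, > 50000 nM. Among the compounds with values here, the one computable step, an at least 4.0-fold lower number from compound 1 to compound 2 (0.60 log units; beyond the scatter), is bounded by the limit of > 50000 nM in this assay, at which 2 of the 3 values shown sit, and can only be read as a floor.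

Compound 4, `COc1cc(/C=C/C(=O)OCCCCCCO[N+](=O)[O-])ccc1O`, is not yet measured. It differs from compound 2 by (nitrooxy)methyl in place of nitrooxy on a saturated chain carbon, five bonds along the chain from an oxygen next to a carbonyl group. Within the data shown here, the only measured step concerns the phenol oxygen, not the ester chain, so no measured step bears directly on this change; the set offers no evidence of the chain length mattering either way. Accordingly a step within the scatter is expected in this assay, no change at the digits printed from compound 2 to compound 4 (within the scatter). Compound 4 is expected to give 12300 nM, with the estimate spanning 5000 nM to 30000 nM.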

Compound 4, half-maximal inhibitory concentration: > 50000 nM
Compound 4: no number, only a limit; the forecaster's own chance of this, stated with the estimate: 15%; at least 4.0-fold (0.60 log units) between middle value and limit.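

Going by these compounds alone, the ester chain, which the one earlier step did not touch, now proves sensitive in this assay: (nitrooxy)methyl in place of nitrooxy on a saturated chain carbon, five bonds along the chain from an oxygen next to a carbonyl group, gives an at least 4.0-fold higher number from compound 2 to compound 4 (0.60 log units; beyond the scatter). Keeping the free phenol is therefore not enough to hold a measurable number, since compound 4 retains that phenol and differs from compound 2 only in this chain. Compound 4 gives only a limit, so the size of this step is a lower bound, and the series has a single actual number: the limit of > 50000 nM in this assay, at which 3 of the 4 values shown sit.

Still open, on these data alone, is whether a shorter chain, such as a 4-(nitrooxy)butyl ester, would give a number in this assay, which would show whether the 5-(nitrooxy)pentyl chain of compound 2 is an isolated case or part of a wider range. Also open, as far as these compounds go, is whether a hydroxyl in place of nitrooxy on the chain of compound 2 would hold the number, which would separate the contribution of the chain from that of the nitrooxy group.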